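Notes on a triazole thioether amide series, N-substituent step

The source may hold more compounds than are shown below. What is called first, only, known or untested is meant among the compounds shown, and "the series" means these compounds.

Measured so far in an assay on 32D cells for inhibition of interleukin-15 (Mus musculus), read by resazurin assay, with stated times of 30 min and 2.5 days, in the presence of a further agent that is not named here; on this read-out lower numbers stand for stronger inhibition and higher numbers for weaker inhibition:
- compound 1 `Cn1nc(Cc2nnc(SCCCCCCCC(=O)Nc3ccc(Cl)cc3Cl)[nH]2)c2ccccc2c1=O` gives 1100 nM
- compound 2 `Cn1nc(Cc2nnc(SCCCCCCCC(=O)Nc3ccc(Cl)cc3Cl)n2CCCO[Si](C)(C)C(C)(C)C)c2ccccc2c1=O` gives > 30000 nM, which is a limit of the assay and not a number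

Compound 2 therefore stands at the weak end of what the assay can report; of the two values shown, it is the one sitting at the limit of > 30000 nM in this assay, at which 1 of the 2 values shown sits. Among the compounds with values here, the only measured step is an at least 27-fold higher number from compound 1 to compound 2 (1.43 log units; beyond the scatter), and it runs in the direction of a weaker read-out when the bulky silicon-bearing chain is put on the aromatic nitrogen of the shared core.

The next compound, compound 3 `CN(C)CCCn1c(Cc2nn(C)c(=O)c3ccccc23)nnc1SCCCCCCCC(=O)Nc1ccc(Cl)cc1Cl`, keeps a chain on that nitrogen but ends it differently: a group of 3 heavy atoms (2 carbon, 1 nitrogen; no ring) in place of a group of 8 heavy atoms (6 carbon, 1 oxygen, 1 silicon; no ring), on a saturated chain carbon, three bonds along the chain from an aromatic nitrogen. Within the data shown here, no measured pair shows this exchange. The step from compound 1 to compound 2 bears on it only indirectly, in that it shows the silicon-bearing chain to be poorly tolerated; how much of that loss is undone by the shorter, nitrogen-containing end is not known from the data.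

Compound 3 is therefore expected to return a number rather than a limit, with the step estimated as an at least 3.7-fold lower number from compound 2 to compound 3 (0.57 log units; beyond the scatter), but with a wide range. The estimate for compound 3 in this assay is 8000 nM, between 1500 nM and 30000 nM.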

Compound 3, half-maximal inhibitory concentration: 3700 nM
Compound 3: the middle estimate sits 2.2-fold (0.33 log units) above what was measured; low and high end bracket the measured number.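

In this assay, a chain on the aromatic nitrogen does not by itself push the read-out to the limit: 3-(dimethylamino)propyl in place of hydrogen still carries a cost, but a moderate one, with a 3.4-fold higher number from compound 1 to compound 3 (0.53 log units; beyond the scatter). At the end of the chain, dimethylamino in place of the silicon-bearing group gives an at least 8.1-fold lower number from compound 2 to compound 3 (0.90 log units; beyond the scatter), so across these three compounds the read-out depends on what ends the chain and not only on whether a chain is present. Compound 2 gives a limit and not a number, so this step has a bound but no exact size: the limit of > 30000 nM in this assay, at which 1 of the 3 values shown sits.

From the compounds shown here alone, it remains open whether the nitrogen of the dimethylamino end matters or whether the smaller end alone accounts for the difference, a question that a plain propyl chain or a chain ending in a hydroxyl group would address. Also open, going by these compounds, is how the read-out responds to a carboxylic acid or a morpholine at the chain end, or to a longer or shorter carbon chain between the aromatic nitrogen and the amine.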